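This account rests on a few compounds, and the source may have more. Where it says the series, first, only, none or still open, it means among the compounds named here.

In an ADME assay on A549 cells (Homo sapiens) for cytotoxicity, read by MTT assay (a higher number here means that more compound is tolerated, a lower number that less compound is tolerated), compound 1 (`C#CCN(c1ccccc1C)S(=O)(=O)c1cc(Cl)ccc1Cl`) gives only the limit > 5000 nM and no number. Among the compounds with values here, compound 2 (`C#CCN(c1ccc(Cl)cc1C)S(=O)(=O)c1cc(Cl)ccc1Cl`) also gives only a limit, with > 5000 nM as its sole reading. The record so far is the limit of > 5000 nM in this assay, at which 2 of the 2 values shown sit, and nothing more. Compound 3 (`Cc1cc(Cl)ccc1N(C(F)F)S(=O)(=O)c1cc(Cl)ccc1Cl`) differs from compound 2 by difluoromethyl in place of propargyl on a sulfonamide nitrogen with difluoromethyl in place of propargyl on a sulfonamide nitrogen. Within the data shown here, the one measured step is a step that the two limits leave unreadable from compound 1 to compound 2 and it concerns chloro in place of hydrogen on an aromatic carbon, so it gives no size to carry over. Among the measured compounds shown here, no measured step touches the group on the sulfonamide nitrogen. In this assay no step beyond the scatter can be argued in either direction. The expected change is a step that the limit leaves unreadable from compound 2 to compound 3 and this remains a weakly founded estimate. For compound 3 the estimated value is 8000 nM with an expected range from 2500 nM to 25000 nM in this read-out.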

Compound 3, half-maximal cytotoxic concentration: > 5000 nM
Compound 3: only a limit was reported (the forecaster's own chance of this, stated with the estimate: 75%); the middle value does not contradict the limit.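

Compound 2 and compound 3 both give only limits in this assay, so no new step can be read between them: the limit of > 5000 nM in this assay, at which 3 of the 3 values shown sit.

Left open: the concentration at which any of these compounds becomes cytotoxic in this assay, and whether difluoromethyl in place of propargyl on a sulfonamide nitrogen shifts it.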